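The source may report more compounds than this note shows. Statements on the series, on what has been measured and on what is new or still open speak of the compounds shown alone.

Among the measured compounds shown here, in a functional assay on cells (Cancer cell lines, Homo sapiens) for inhibition (on this read-out higher numbers stand for weaker inhibition of growth and lower numbers for stronger inhibition of growth), compound 1 `Cc1cn2c(/C=N/NC(=N)N)c(-c3ccsc3)nc2s1` gives 7760 nM as the lower of the two numbers so far, and compound 2 `N=C(N)N/N=C/c1c(-c2ccsc2)nc2sccn12` gives 17400 nM as the higher. For the measured compounds named here, the only measured step (a 2.2-fold higher number from compound 1 to compound 2 (0.35 log units; beyond the scatter)) is modest and is hydrogen in place of methyl on an aromatic carbon, not a change of the thiophene attachment. Compound 3 `Cc1cn2c(/C=N/NC(=N)N)c(-c3cccs3)nc2s1` keeps that methyl and has thiophen-2-yl in place of thiophen-3-yl on an aromatic carbon. Going by the values given here, no measured step covers such a swap, so no change beyond the scatter is expected in this assay in either direction. The estimated step is small (a 1.0-fold higher number from compound 1 to compound 3 (0.01 log units; within the scatter)). Compound 3 is expected at 8000 nM (estimated range 3500 nM to 18000 nM).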

Compound 3, concentration for 50% growth inhibition: 5750 nM
Estimate against measurement, compound 3: 1.4-fold (0.14 log units) above; the range from low to high includes it.
By their numbers in this assay, from the lowest: compounds 3 and 1 (each within the scatter of the next); then compound 2.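

Swapping thiophen-3-yl for thiophen-2-yl on this aromatic carbon gives a 1.3-fold lower number from compound 1 to compound 3 (0.13 log units; within the scatter) in this assay, so the attachment point of the thiophene does not separate these two compounds here. At this position, the swap therefore stays within the scatter, unlike the methyl step elsewhere on the core, a 2.2-fold higher number from compound 1 to compound 2 (0.35 log units; beyond the scatter). No evidence is available on what lies behind this result.

As far as these compounds go, whether a phenyl, a pyridine or an amine at this position would shift the number remains open. So does whether the thiophene swap reads the same without the methyl.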